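From 4-methylphenyl to 2-methylphenyl

This account rests on a few compounds, and the source may have more. Where it says the series, first, only, none or still open, it means among the compounds named here.

In a functional assay on SK-MEL-2 cells (Homo sapiens) for cytotoxicity (on this read-out lower numbers stand for stronger inhibition and higher numbers for weaker inhibition), compound 1 `Cc1ccc2c(O)nc(-c3ccccc3C)cc2c1` gives 2630 nM and compound 2 `Cc1ccc(-c2cc3cc(C)ccc3c(N3CCN(C)CC3)n2)cc1` gives 2400 nM so compound 2 stands level with compound 1, within the usual scatter. Compound 3 `Cc1ccc2c(N3CCN(C)CC3)nc(-c3ccccc3C)cc2c1` has the same atoms as compound 2, joined differently: 2-methylphenyl in place of 4-methylphenyl on an aromatic carbon is the whole change. Among the compounds with values here, no measured pair shows this change alone. Compound 1 also carries 2-methylphenyl and gives 2630 nM without the 4-methylpiperazin-1-yl group. The estimated 1.0-fold higher number from compound 2 to compound 3 (0.02 log units; within the scatter) stays within the scatter. For compound 3 the expected value is 2500 nM with a range from 800 nM to 8000 nM.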

Compound 3, half-maximal inhibitory concentration: 3380 nM
Estimate against measurement, compound 3: 1.4-fold (0.13 log units) below, within the range that was stated.
By their numbers in this assay, from the lowest: compounds 2, 1 and 3 (each within the scatter of the next).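

In this assay the pair compound 2 and compound 3 shows 2-methylphenyl in place of 4-methylphenyl alone on this aromatic carbon, with a 1.4-fold higher number from compound 2 to compound 3 (0.15 log units; within the scatter) as the step, so the two groups cannot be told apart here. With 2-methylphenyl kept, 4-methylpiperazin-1-yl in place of hydroxy gives a 1.3-fold higher number from compound 1 to compound 3 (0.11 log units; within the scatter) and so also leaves no readable difference. Nothing at hand offers an explanation for either result. Still open, as far as these compounds go, is how 3-methylphenyl at this position would compare, or a phenyl ring carrying an amine or a carboxylic acid instead of the methyl.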